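A Second Chloro on a Compound at the Limit

The source may hold more compounds than are shown below. What is called first, only, known or untested is meant among the compounds shown, and "the series" means these compounds.

In an ADME assay on MDBK cells (Bos taurus) for cytotoxicity, read by MTT assay, with a stated time of 96 h (on this read-out higher numbers stand for lower toxicity in this test and lower numbers for higher toxicity in this test), compound 3 `Clc1ccc(/N=N/N2CCCC2)cc1` gives > 100000 nM, which is a limit of the assay and not a number. Compound 1 `Clc1cccc(/N=N/N2CCCC2)c1` gives > 100000 nM, also a limit. Compound 2 `c1ccc(/N=N/N2CCCC2)cc1` gives > 100000 nM, again a limit. For the measured compounds named here, the series so far therefore stands at the limit of > 100000 nM in this assay, at which 3 of the 3 values shown sit.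

Compound 4 `Clc1ccc(/N=N/N2CCCC2)cc1Cl` differs from compound 3 by one change: chloro in place of hydrogen on an aromatic carbon. A chloro takes the place of hydrogen on an aromatic carbon, ortho to a chloro group and meta to a group of 7 heavy atoms.

Two measured steps swap chloro and hydrogen on an aromatic carbon: a step that the two limits leave unreadable from compound 1 to compound 2, and a step that the two limits leave unreadable from compound 2 to compound 3. Neither has a readable size, so both offer only weak guidance. Neither chloro compound, compound 1 with > 100000 nM or compound 3 with > 100000 nM, came off the limit, so no step beyond the scatter is expected in this assay. The expected change is a number no higher from compound 3 to compound 4 (the limit leaves the size open). For compound 4 the estimated value is 100000 nM, with an expected range from 50000 nM to 200000 nM.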

Compound 4, half-maximal cytotoxic concentration: 70000 nM
The estimate for compound 4 lay 1.4-fold (0.15 log units) above the measured number; low and high end bracket the measured number.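

With a second chloro, ortho to a chloro group, the series gets its first readable number in this assay: compound 4 gives 70000 nM. The two new steps are an at least 1.4-fold lower number from compound 3 to compound 4 (0.15 log units; that floor lies within the scatter) and an at least 1.4-fold lower number from compound 1 to compound 4 (0.15 log units; that floor lies within the scatter). Each of these is only a floor, so the data show a value that can be read at this position, but not how large the change truly is, and the other compounds stay without a number: the limit of > 100000 nM in this assay, at which 3 of the 4 values shown sit.

The compounds shown carry only chloro or hydrogen on the aromatic ring, so it remains open whether a different group at this position, such as a methoxy, an amine or a carboxylic acid, would also give a readable number. On these data alone, how a larger group in place of the chloro would compare with compound 4 also remains open.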